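The source may hold more compounds than are shown below. What is called first, only, known or untested is meant among the compounds shown, and "the series" means these compounds.

Of the compounds shown here, three of one shared core have been measured in a functional assay on CHO cells for positive allosteric modulation of metabotropic glutamate receptor 2 (Homo sapiens), with a stated time of 30 min; on this read-out higher numbers stand for an effect only at larger amounts of compound and lower numbers for an effect already at smaller amounts. Compound 1 `CC(C)CCn1ccc(N2CCc3ccccc3C2)c(C#N)c1=O` gives 871 nM. Compound 2 `CCCCn1ccc(N2CCC(c3ccccc3)CC2)c(C#N)c1=O` gives 95 nM. Compound 3 `CC(C)Cn1ccc(N2CCC(c3ccccc3)CC2)c(C#N)c1=O` gives 282 nM, the second highest of the three numbers: compound 2 sits at a lower number and compound 1 at a higher one, and both gaps are beyond the scatter.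

Among the measured compounds shown here, the only step in the set that changes the same place is a 3.0-fold higher number from compound 2 to compound 3 (0.47 log units; beyond the scatter), a modest rise. Compound 4 `N#Cc1c(N2CCC(c3ccccc3)CC2)ccn(CC2CC2)c1=O` differs from compound 3 by cyclopropyl in place of isopropyl on a saturated chain carbon bound to an aromatic nitrogen, which, cut one bond further out, reads isobutyl to cyclopropylmethyl. For the measured compounds named here, the step from compound 2 to compound 3 shows that this position answers to branching, but it does not tell how a three-membered ring in place of the isopropyl will read, and no other measured pair speaks to it. With the leaving and entering groups matched in heavy-atom count, the expected step in this assay is a small one, a 1.4-fold lower number from compound 3 to compound 4 (0.15 log units; within the scatter), not clearly beyond the scatter, with a lean towards a lower number. Compound 4 is therefore estimated at 200 nM, with a range from 70 nM to 600 nM.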

Compound 4, half-maximal effective concentration: 151 nM
Estimate against measurement, compound 4: 1.3-fold (0.12 log units) above; the range from low to high includes it.
By their numbers in this assay, from the lowest: compounds 2, 4 and 3 (each within the scatter of the next, the first and the last beyond it); then compound 1.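

In this assay, the position on the saturated chain carbon bound to the aromatic nitrogen now has a third substituent, and the new ring does not clearly separate from either neighbour: the steps are a 1.9-fold lower number from compound 3 to compound 4 (0.27 log units; within the scatter) and a 1.6-fold higher number from compound 2 to compound 4 (0.20 log units; within the scatter). Earlier, the step of a 3.0-fold higher number from compound 2 to compound 3 (0.47 log units; beyond the scatter) showed only that exchanging propyl for isopropyl moves the number beyond the scatter, whereas cyclopropyl, with the same heavy-atom count as isopropyl, sits within the scatter of both compound 2 and compound 3, so these three compounds no longer fall into two clearly separate levels at this position. The compounds offer no independent measurement that would explain these numbers, and none that bears on the result.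

Still open, as far as these compounds go, is how far this position reaches: whether a cyclobutyl group, a longer chain or a chain carrying an ether oxygen would stay within the scatter of compound 4 or move beyond it. Among the compounds shown here, also open is whether cyclopropyl in place of isopropyl reads the same way when the amine part of the molecule is the one carried by compound 1 rather than the one shared by compound 2, compound 3 and compound 4.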